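Two Limits and an Added Fluoro

This account rests on a few compounds, and the source may have more. Where it says the series, first, only, none or still open, it means among the compounds named here.

Compound 1 `CNc1cc(=O)[nH]c(=O)n1[C@@H]1O[C@H](CO)[C@@H](O)[C@H]1O`: > 50000 nM
Compound 2 `O=Cc1cc(=O)[nH]c(=O)n1[C@@H]1O[C@H](CO)[C@@H](O)[C@H]1O`: > 50000 nM

In a functional assay on MDA-MB-468 cells (Homo sapiens) for antiproliferative activity, read by WST assay, with a stated time of 3 days (on this read-out higher numbers stand for weaker inhibition and lower numbers for stronger inhibition), compound 2 gives > 50000 nM, which is a limit of the assay and not a number. Both measured compounds stand at the same point: the limit of > 50000 nM in this assay, at which 2 of the 2 values shown sit. Among the measured compounds shown here, the only measured step is a step that the two limits leave unreadable from compound 1 to compound 2, so it offers no size to carry forward. Compound 3 `O=Cc1c(F)c(=O)[nH]c(=O)n1[C@@H]1O[C@H](CO)[C@@H](O)[C@H]1O` has fluoro in place of hydrogen on an aromatic carbon, ortho to a formyl group (fluoro in place of hydrogen on an aromatic carbon). Little change is therefore expected in this assay, with at most a modest move towards stronger inhibition and another limit quite likely. The expected step is an at least 1.2-fold lower number from compound 2 to compound 3 (0.09 log units; that floor lies within the scatter). For compound 3 the estimate is 40000 nM, with an expected range of 5000 nM to 80000 nM.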

Compound 3, half-maximal inhibitory concentration: 1900 nM
Estimate against measurement, compound 3: 21-fold (1.32 log units) above; measured number below the stated range.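

In this assay, among the compounds shown here, fluoro in place of hydrogen on this aromatic carbon, ortho to a formyl group, gives an at least 26-fold lower number from compound 2 to compound 3 (1.42 log units; beyond the scatter), so this position answers strongly to a single added atom, which the earlier compounds could not show. Compound 1 and compound 2 stay at a limit of the assay, not a number, and the step between them cannot be read: the limit of > 50000 nM in this assay, at which 2 of the 3 values shown sit.

As far as these compounds go, what chloro, methyl or an amine on this carbon would do stays open. So does whether fluoro would bring a similar step with methylamino in place of the formyl group.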